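This account rests on a few compounds, and the source may have more. Where it says the series, first, only, none or still open, it means among the compounds named here.

Two compounds have numbers in an assay for inhibition of serine/threonine-protein kinase Sgk1 (Homo sapiens), with stated times of 30 min and 60 min, in the presence of a further agent that is not named here; a lower number here means a stronger inhibitor, a higher number a weaker inhibitor. Compound 1, with the structure `CC(C)N1CC[C@H](NC(=O)c2cc(-c3ccc(NS(=O)(=O)c4cccc(Cl)c4Cl)cc3)nc3[nH]ncc23)C1`, gives 38 nM. Compound 2, with the structure `Cc1n[nH]c2nc(-c3ccc(NS(=O)(=O)c4cc(Cl)ccc4F)cc3)nc(OCCC(=O)N(C)C)c12`, gives 438 nM. Of the two, compound 2 stands at the higher number, and the gap to compound 1 is beyond the usual scatter of repeated measurements. Compound 1 and compound 2 differ in more than one place, so no single change can be credited for that gap.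

The step to compound 3, with the structure `Cc1n[nH]c2nc(-c3ccc(NS(=O)(=O)c4cc(Cl)ccc4F)cc3)nc(OC3CC(C)(C)NC(C)(C)C3)c12`, changes one place: 2,2,6,6-tetramethylpiperidin-4-yl in place of 2-(dimethylcarbamoyl)ethyl on an oxygen on an aromatic ring. The oxygen on the aromatic ring keeps its position; only what hangs from it changes, a chain without a ring giving way to a six-membered non-aromatic ring with one hydrogen-bond donor. For the measured compounds named here, no measured pair shows this exact change, so the direction of the step cannot be read from a neighbour. Going by the values given here, for compound 3 the expected step from compound 2 to compound 3 is a 2.9-fold lower number from compound 2 to compound 3 (0.47 log units; beyond the scatter), a modest move toward a lower number, with a wide range because no comparable step is known. Compound 3 is thus estimated to give 150 nM, expected between 40 nM and 600 nM.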

Compound 3, half-maximal inhibitory concentration: 4 nM
For compound 3 the middle estimate is 38-fold (1.57 log units) above the measured one; the measured number lies below the stated range.
By their numbers in this assay, from the lowest: compound 3; then compound 1; then compound 2.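

On the oxygen on the aromatic ring, the choice of group has a large effect in this assay: 2,2,6,6-tetramethylpiperidin-4-yl in place of 2-(dimethylcarbamoyl)ethyl gives a 110-fold lower number from compound 2 to compound 3 (2.04 log units; beyond the scatter). For the compounds shown here, this is the first pair here that differs in one place, so, unlike the gap between compound 1 and compound 2, this step can be tied to a single structural change. The change replaces a chain without a ring and without a hydrogen-bond donor with a six-membered non-aromatic ring carrying one hydrogen-bond donor, but no measurement at hand explains the fall in the number, so the step records an outcome and not a cause.

This single pair cannot separate the contribution of the ring itself from that of its four methyl groups or its ring nitrogen; a plain piperidin-4-yl or a cyclohexyl group on the same oxygen would help to tell these apart. It also leaves open whether the 2,2,6,6-tetramethylpiperidin-4-yl group would have a similar effect on the core of compound 1.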